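The source may report more compounds than this note shows. Statements on the series, on what has been measured and on what is new or still open speak of the compounds shown alone.

Compound 1 `CS(=O)(=O)c1ccc(C(=O)N2CCC(C(=O)N3CCN(c4ccc(F)cc4)CC3)CC2)cc1[N+](=O)[O-]` was tested in an assay on isolated protein for inhibition of thyroid hormone receptor beta (Homo sapiens), read by fluorescence polarization; on this read-out higher numbers stand for weaker inhibition and lower numbers for stronger inhibition. In this assay compound 1 gives > 60000 nM, which is a limit of the assay rather than a measured number. Compound 2 `Cc1ccc(N2CCN(C(=O)CCCNC(=O)c3ccc(S(C)(=O)=O)c([N+](=O)[O-])c3)CC2)cc1` was tested in the same way: in this assay compound 2 gives > 60000 nM, again only a limit. Among the measured compounds shown here, compound 1 therefore stands where every value shown here stands, at the limit of > 60000 nM in this assay, at which 2 of the 2 values shown sit, and no step between two measured numbers is available to show how any change moves the read-out.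

Compound 3 `CS(=O)(=O)c1ccc(C(=O)N2CCC(C(=O)N3CCN(c4ccccc4)CC3)CC2)cc1[N+](=O)[O-]` has not yet been measured in this assay. It differs from compound 1 in one place: hydrogen in place of fluoro on an aromatic carbon. The fluoro group gives way to hydrogen on an aromatic carbon, and nothing else in the shared core is touched.

With compound 1 resting at a limit, the step from compound 1 to compound 3 is expected to be a step that the limit leaves unreadable from compound 1 to compound 3, that is, no movement beyond the usual scatter. Compound 3 is thus expected to give 80000 nM, within a range of 30000 nM to 200000 nM, and most probably it will again be reported only as a limit.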

Compound 3, half-maximal inhibitory concentration: > 60000 nM
Compound 3 gave a limit, no number; the forecaster's own chance of this, stated with the estimate: 85%; the middle value does not contradict the limit.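

Among the compounds shown here, compound 1 and compound 3 rest at the same limit, not at measured numbers, so no step between them can be read and the exchange of fluoro for hydrogen has no readable size: the limit of > 60000 nM in this assay, at which 3 of the 3 values shown sit. In this assay the compounds shown leave open how strongly each inhibits the receptor, and whether any change to the shared core would give a measured number.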